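Para fluoro for ethyl in a phenethyl urea series

The source may hold more compounds than are shown below. What is called first, only, known or untested is meant among the compounds shown, and "the series" means these compounds.

Measured so far:
compound 1, `CCc1ccc(NC(=O)N[C@H](C)c2ccccc2)cc1`; in an ADME assay on the whole organism with Oryza sativa as the target, tested at 0.1 uM (on this read-out lower numbers stand for a stronger effect and higher numbers for a weaker effect at the one concentration tested), compound 1 gives 95%
compound 2, `CCc1ccc(NC(=O)N[C@@H](C)c2ccccc2)cc1`; compound 2 gives 99%
compound 3, `C[C@@H](NC(=O)Nc1ccccc1C(C)(C)C)c1ccccc1`; compound 3 gives 100%

Compound 2 stands second highest of the three numbers, with compound 3 above and compound 1 below it, both within the scatter. Going by the values given here, the only measured step, a number 4 percentage points higher from compound 1 to compound 2 (within the scatter), rests on the fact that compounds 1 and 2 differ only in the configuration as drawn and leaves the aromatic substituents untouched, so it does not bear on the change to compound 4, `C[C@H](NC(=O)Nc1ccc(F)cc1)c1ccccc1`, in which (fluoro in place of ethyl on an aromatic carbon). Among the compounds with values here, no measured pair shows what this exchange does. Compound 2 and compound 3 carry different ring substituents yet give numbers within the scatter of each other, so little movement is expected. The step from compound 2 to compound 4 is expected to be a number 3 percentage points lower from compound 2 to compound 4 (within the scatter), none beyond the scatter. Compound 4 is therefore estimated at 96%, between 86% and 100%.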

Compound 4, a percentage reported as activity, at one concentration (the size of the read-out at that concentration, not a potency): 96%
Compound 4: middle estimate and measured number agree at the digits printed; low and high end bracket the measured number.
By their numbers in this assay, from the lowest: compounds 1, 4, 2 and 3 (each within the scatter of the next).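

In this assay, fluoro in place of ethyl on an aromatic carbon, para to a large group, gives a number 3 percentage points lower from compound 2 to compound 4 (within the scatter). Going by these compounds alone, this is the only exchange of a substituent at this position that can be read from a matched pair, and on this pair the read-out does not separate fluoro from ethyl. Nothing at hand accounts for this result.

As far as these compounds go, whether an amine, a carboxylic acid or a longer chain at this position would move the read-out beyond the scatter stays open. Also open, from the compounds shown here alone, is how fluoro behaves with the opposite configuration as drawn at the stereocentre.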